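Swapping the aryl group on the pyrazoline core

This account rests on a few compounds, and the source may have more. Where it says the series, first, only, none or still open, it means among the compounds named here.

Measured so far:
- compound 1, `Cc1cccc(N2N=C(C(C)(C)C)CC2c2ccc(O)cc2)c1`: 91.7%
- compound 2, `Cc1ccc(N2N=C(C(C)(C)C)CC2c2ccc(O)cc2)c(C)c1`: 59.9%

Both compounds were tested in an assay on isolated protein for inhibition of protein kinase C zeta type (Homo sapiens), with a stated time of 4 min, tested at 62.5 uM; a higher number here means more inhibition at the concentration tested (going by the name of the read-out), a lower number less inhibition. Among the measured compounds shown here, compound 2 stands at the lower of the two numbers; the only other compound, compound 1, lies higher, and the one step between them, a number 31.8 percentage points lower from compound 1 to compound 2 (beyond the scatter), is beyond the scatter. That step concerns 2,4-dimethylphenyl in place of 3-methylphenyl on an amine nitrogen in a ring.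

The next compound, compound 3, `CC(C)(C)C1=NN(c2ccc(F)c(Cl)c2)C(c2ccc(O)cc2)C1`, differs from compound 2 in one place: 3-chloro-4-fluorophenyl in place of 2,4-dimethylphenyl on an amine nitrogen in a ring. For the measured compounds named here, no measured step covers this exact change, so only the two values shown can guide a guess. Compound 1, which carries a single group in the 3-position of its phenyl, gives the higher number, and compound 3 also carries a group in that position while losing the 2-substituent. The expectation is therefore a rise from compound 2 to compound 3 of about a number 20.1 percentage points higher from compound 2 to compound 3 (beyond the scatter), bringing compound 3 to an estimated 80%, within 55% to 96%.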

Compound 3, a percentage reported as inhibition, at one concentration (the size of the read-out at that concentration, not a potency): 98.8%
The estimate for compound 3 lay 18.8 percentage points below the measured number; the measured number lies above the stated range.
By their numbers in this assay, from the lowest: compound 2; then compounds 1 and 3 (each within the scatter of the next).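

In this assay, replacing 3-methylphenyl with 3-chloro-4-fluorophenyl on the amine nitrogen in a ring gives a number 7.1 percentage points higher from compound 1 to compound 3 (within the scatter), so this single reading cannot tell these two groups apart, even though a methyl group has given way to chlorine and fluorine. The same 3-chloro-4-fluorophenyl group, set against 2,4-dimethylphenyl, gives a number 38.9 percentage points higher from compound 2 to compound 3 (beyond the scatter), which is about as large as the earlier gap between compound 1 and compound 2 and leaves 2,4-dimethylphenyl as the only one of the three aryl groups with a clearly lower number. Nothing available here explains why this aryl group stands apart from the other two.

Going by these compounds, whether the lower number of compound 2 comes from one methyl group or from the pair stays open, and a comparison of 2-methylphenyl with 4-methylphenyl on the same core would begin to separate the two. On these data alone, the tert-butyl and 4-hydroxyphenyl groups are the same in all three compounds, so it is also open how an amine or a carboxylic acid in place of the hydroxyl group would change the inhibition.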